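This account rests on a few compounds, and the source may have more. Where it says the series, first, only, none or still open, it means among the compounds named here.

Compound 1 `CCOC(=O)c1ccnc(-c2ccc(OCC)cc2)c1` gives 80000 nM in an assay on COS-7 cells for inhibition of patatin-like phospholipase domain-containing protein 2 (Mus musculus); a lower number here means a stronger inhibitor, a higher number a weaker inhibitor. Compound 2 `CCOC(=O)c1cncc(-c2ccc(OCC)cc2)c1` gives 130000 nM in this assay. Compound 3 `CCOC(=O)c1cccc(-c2ccc(CN(C)C)o2)c1` gives 190000 nM in this assay.

Compound 3 stands at the highest of the three numbers; compound 2 lies within the scatter of it, whereas compound 1 lies beyond the scatter, at a lower number. For the measured compounds named here, no pair of measured compounds differs in a single place, so no measured step frames the change that follows. Compound 4 `CCOC(=O)c1cccc(-c2ccc(CN3CCN(C)CC3)o2)c1` carries 4-methylpiperazin-1-yl in place of dimethylamino on a saturated chain carbon bound to an aromatic carbon. Going by the values given here, with no comparable step among the measured compounds, the step from compound 3 to compound 4 in this assay is expected to be a 1.1-fold lower number from compound 3 to compound 4 (0.05 log units; within the scatter), that is, no move beyond the scatter in either direction. Compound 4 is estimated at 170000 nM, in the range 60000 nM to 450000 nM.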

Compound 4, half-maximal inhibitory concentration: 120000 nM
For compound 4 the middle estimate is 1.4-fold (0.15 log units) above the measured one, within the range that was stated.
By their numbers in this assay, from the lowest: compounds 1, 4, 2 and 3 (each within the scatter of the next, the first and the last beyond it).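

In this assay, 4-methylpiperazin-1-yl in place of dimethylamino on a saturated chain carbon bound to an aromatic carbon gives a 1.6-fold lower number from compound 3 to compound 4 (0.20 log units; within the scatter). For the compounds shown here, this is the first single-place comparison, and it shows that exchanging the open dimethylamino group for this larger ring-bearing group leaves the number within the scatter. Nothing available here bears on why this is so. On these data alone, it remains open whether morpholin-4-yl or a primary amine on that carbon would move the number beyond the scatter, and whether a carboxylic acid in place of the ethyl ester would do so.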